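Dropping a Methoxy Group: What Compound 3 May Show

The source may report more compounds than this note shows. Statements on the series, on what has been measured and on what is new or still open speak of the compounds shown alone.

Measured so far:
- Compound 1, `COc1cc(-c2cc(/C=C/C(=O)c3ccc(N)cc3)[nH]n2)cc(OC)c1OC`, gives -81% in a functional assay on TK-10 cells (Homo sapiens) for cytotoxicity, read by sulforhodamine B assay, with a stated time of 48 h, tested at 100 uM; on this read-out lower numbers stand for a stronger effect and higher numbers for a weaker effect at the one concentration tested.
- Compound 2, `COc1cc(-c2cc(/C=C/C(=O)c3ccc(Cl)c(Cl)c3)[nH]n2)cc(OC)c1OC`, gives -27% in this assay.

Compound 1 stands lowest of the two numbers in this assay, and its nearest neighbour is compound 2, which lies a number 54 percentage points higher from compound 1 to compound 2 (beyond the scatter). That step came from swapping the group on the carbonyl carbon, so it says nothing about the other side of the shared core.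

Compound 3, `COc1ccc(-c2cc(/C=C/C(=O)c3ccc(N)cc3)[nH]n2)cc1OC`, keeps the carbonyl side of compound 1 unchanged and differs only in this: hydrogen in place of methoxy on an aromatic carbon. Among the compounds with values here, no measured pair shows what taking away one methoxy group from this ring does, so the only anchor is the value of compound 1 itself. With nothing pointing either way, the expectation for this assay is a step of no clear direction, quite possibly within the scatter, and the range must stay wide. Compound 3 is therefore estimated at -70%, between -95% and -35%, which would mean a change of a number 11 percentage points higher from compound 1 to compound 3 (beyond the scatter).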

Compound 3, a percentage reported as activity, at one concentration (the size of the read-out at that concentration, not a potency): -98%
The estimate for compound 3 lay 28 percentage points above the measured number, and the stated range ends above it.
By their numbers in this assay, from the lowest: compound 3; then compound 1; then compound 2.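

In this assay, putting hydrogen in place of the methoxy group on the aromatic carbon ortho to a methoxy group and meta to a large group gives a number 17 percentage points lower from compound 1 to compound 3 (beyond the scatter), a shift towards a stronger effect at the one concentration tested. Within the data shown here, this is the first sign that the methoxy side of the shared core also affects the read-out, and that this methoxy group is not needed for a strong effect in compound 1; the earlier step, a number 54 percentage points higher from compound 1 to compound 2 (beyond the scatter), changed only the group on the carbonyl carbon. No available evidence explains why removing this methoxy group strengthens the effect.

The compounds shown leave open whether the same change would strengthen the effect with the 3,4-dichlorophenyl group of compound 2 in place of the 4-aminophenyl group, since this single step comes from the 4-aminophenyl series alone. They also leave open whether the gain comes from losing the methoxy group altogether or would persist with a different group on that carbon, such as a hydroxyl group, a fluorine atom or an ethoxy group.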